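The source may report more compounds than this note shows. Statements on the series, on what has been measured and on what is new or still open speak of the compounds shown alone.

Measured so far: compound 1 `COc1ncnc2c1c(I)cn2[C@@H]1O[C@H](CO)[C@@H](O)[C@H]1O`, > 20000 nM; compound 2 `O=c1[nH]cnc2c1c(-c1cc3ccccc3o1)cn2[C@@H]1O[C@H](CO)[C@@H](O)[C@H]1O`, > 20000 nM.

In a functional assay on HCT-116 cells (Homo sapiens), read by MTT assay, with a stated time of 72 h (a lower number here means a stronger inhibitor, a higher number a weaker inhibitor), compound 1 gives > 20000 nM, which is a limit of the assay rather than a number. Compound 2 likewise gives > 20000 nM, also a limit. Both values sit at the limit of > 20000 nM in this assay, at which 2 of the 2 values shown sit, so compound 1 stands at that limit with nothing to rank it against. Compound 3 `COc1ncnc2c1c(-c1ccco1)cn2[C@@H]1O[C@H](CO)[C@@H](O)[C@H]1O` is not yet measured; it differs from compound 1 by furan-2-yl in place of iodo on an aromatic carbon. Within the data shown here, no measured step covers this change, and no shift beyond the scatter is expected; the expected step is a number no higher from compound 1 to compound 3 (the limit leaves the size open). For compound 3 in this assay the estimate is 20000 nM, between 8000 nM and 50000 nM.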

Compound 3, half-maximal inhibitory concentration: 40 nM
Estimate against measurement, compound 3: 500-fold (2.70 log units) above; the measured number lies below the stated range.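

In this assay, the aromatic carbon two ring bonds from the ring nitrogen turns out to control activity on this core: furan-2-yl in place of iodo gives an at least 500-fold lower number from compound 1 to compound 3 (2.69 log units; beyond the scatter). A single change at this position thus separates a value at the limit of the assay from a measured one. The step is only a bound, as compound 1 stands at a limit: the limit of > 20000 nM in this assay, at which 2 of the 3 values shown sit.

Still open, as far as these compounds go, is whether a phenyl or thiophen-2-yl group at this carbon would match furan-2-yl. Also open, from the compounds shown here alone, is whether the result of compound 3 holds with an amine in place of its methoxy group.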